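Epimer at the methoxy-bearing ring carbon in a staurosporine-type series

The source may hold more compounds than are shown below. What is called first, only, known or untested is meant among the compounds shown, and "the series" means these compounds.

Measured so far in an assay on isolated protein for inhibition of protein kinase C theta type (Homo sapiens), read by HTRF; a higher number here means a weaker inhibitor, a lower number a stronger inhibitor:
- compound 1 `CO[C@@H]1[C@@H](O)[C@@H](O)[C@H]2O[C@]1(C)n1c3ccccc3c3c4c(c5c6ccccc6n2c5c31)C(=O)NC4`: 1010 nM
- compound 2 `CO[C@@H]1[C@@H](O)[C@@H](O)[C@H]2O[C@]1(C)n1c3ccccc3c3c4c(c5c6ccccc6n2c5c31)C(=O)N[C@H]4O`: 2250 nM
- compound 3 `CO[C@H]1NC(=O)c2c1c1c3ccccc3n3c1c1c2c2ccccc2n1[C@@H]1O[C@@]3(C)[C@H](OC)[C@@H](O)[C@H]1O`: 890 nM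

Compound 3 stands at the lowest of the three numbers in this assay, though its gap to compound 1, a 1.1-fold lower number from compound 1 to compound 3 (0.05 log units; within the scatter), is within the scatter, so the two are not separated. Its gap to compound 2 is larger: compound 2 gives the highest number of the three, and the step of a 2.2-fold higher number from compound 1 to compound 2 (0.35 log units; beyond the scatter) is beyond the scatter.

Compound 4 `CO[C@@H]1[C@@H](O)[C@@H](O)[C@H]2O[C@]1(C)n1c3ccccc3c3c4c(c5c6ccccc6n2c5c31)C(=O)N[C@H]4OC` is the unmeasured partner. Relative to compound 3, (the two compounds have the same atoms and bonds and differ only in configuration as drawn: 1 of 6 stereo elements differ; a stereocentre at a saturated ring carbon is drawn R in compound 3 and S in compound 4). Among the measured compounds shown here, no measured pair shows an inversion of configuration, so nothing bears on this change directly. The two steps that touch the same saturated ring carbon are the substitutions a 1.1-fold lower number from compound 1 to compound 3 (0.05 log units; within the scatter) and a 2.2-fold higher number from compound 1 to compound 2 (0.35 log units; beyond the scatter): one within the scatter, the other a modest weakening. Changes at this carbon have so far been small, which argues for a small step in this assay, with no firm direction; a slight weakening is taken as the more likely outcome, as a 1.5-fold higher number from compound 3 to compound 4 (0.16 log units; within the scatter) is expected.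

Compound 4 is therefore estimated at 1300 nM in this assay, with a range of 500 nM to 3500 nM.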

Compound 4, half-maximal inhibitory concentration: > 2500 nM
Compound 4 was reported as a limit (the forecaster's own chance of this, stated with the estimate: 5%); at least 1.9-fold (0.28 log units) between middle value and limit.
By their numbers in this assay, from the lowest: compounds 3 and 1 (each within the scatter of the next); then compound 2. At a limit, above all of these: compound 4.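

The result for compound 4 in this assay is a limit and not a number: the limit of > 2500 nM in this assay, at which 1 of the 4 values shown sits. Inversion at the methoxy-bearing saturated ring carbon gives an at least 2.8-fold higher number from compound 3 to compound 4 (0.44 log units; beyond the scatter), the first sign that configuration at this carbon counts, and this step rests on configuration alone: the fact that compounds 3 and 4 differ only in the configuration as drawn. The methoxy group therefore reads differently in its two configurations, with a 1.1-fold lower number from compound 1 to compound 3 (0.05 log units; within the scatter) for one and an at least 2.4-fold higher number from compound 1 to compound 4 (0.39 log units; beyond the scatter) for the other, while methyl in place of hydrogen on the oxygen gives an at least 1.1-fold higher number from compound 2 to compound 4 (0.04 log units; that floor lies within the scatter), a floor that leaves that pair unseparated.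

How far the inversion step extends past its floor remains open, as does whether the hydroxy group shows the same dependence on configuration, since only one configuration of it appears among these compounds. Also open, on these data alone, is whether an amine or a longer ether such as ethoxy at this carbon would show the same split between the two configurations.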